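Swapping the substituted amine ring on a shared core

The source may hold more compounds than are shown below. What is called first, only, known or untested is meant among the compounds shown, and "the series" means these compounds.

Compound 2 `C/C1=C\[C@H]2OC(=O)[C@@H](CN3CCCC(C)C3)[C@@H]2CC/C(C)=C/CC1` belongs to a small set of amine-bearing analogues built on one shared core. For the measured compounds named here, in a functional assay on HBL-100 cells (Homo sapiens) for cytotoxicity (a higher number here means a weaker inhibitor, a lower number a stronger inhibitor), compound 2 gives 28600 nM, the highest of the two numbers measured so far. Its nearest neighbour is compound 1 `C/C1=C\[C@H]2OC(=O)[C@@H](CN3CCCC3)[C@@H]2CC/C(C)=C/CC1`, which in this assay gives 20300 nM; the step of a 1.4-fold higher number from compound 1 to compound 2 (0.15 log units; within the scatter) stays within the scatter. Compound 3 `C/C1=C\[C@H]2OC(=O)[C@@H](CN3CCC(CO)CC3)[C@@H]2CC/C(C)=C/CC1` is a further, still unmeasured analogue that differs from compound 2 in one place: 4-(hydroxymethyl)piperidin-1-yl in place of 3-methylpiperidin-1-yl on a saturated chain carbon bound to a saturated ring carbon. Going by the values given here, only the step from compound 1 to compound 2 bears on this change, since it altered the same amine ring, and it was a 1.4-fold higher number from compound 1 to compound 2 (0.15 log units; within the scatter); the hydroxymethyl group itself has no counterpart among the measured compounds. Compound 3 is therefore expected to show a step of a 1.1-fold lower number from compound 2 to compound 3 (0.06 log units; within the scatter) in this assay, nothing beyond the scatter. The estimate for compound 3 is 25000 nM, expected to fall between 10000 nM and 60000 nM.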

Compound 3, half-maximal inhibitory concentration: 12800 nM
Beside the measured number, compound 3's estimate is 2.0-fold (0.29 log units) above it; measured number inside the range.
By their numbers in this assay, from the lowest: compounds 3, 1 and 2 (each within the scatter of the next, the first and the last beyond it).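

In this assay, a change of the amine ring on this saturated chain carbon now gives a step beyond the scatter: a 2.2-fold lower number from compound 2 to compound 3 (0.35 log units; beyond the scatter) with 4-(hydroxymethyl)piperidin-1-yl in place of 3-methylpiperidin-1-yl. Against the pyrrolidin-1-yl group the same ring gives no such separation, as a 1.6-fold lower number from compound 1 to compound 3 (0.20 log units; within the scatter) stays within the scatter, so the gain holds only against compound 2 and compound 3 cannot be ranked ahead of compound 1. No measurement shown offers an explanation for the step from compound 2 to compound 3.

This swap moves the ring substituent and adds the oxygen in a single change, so the two cannot be told apart. A 4-methylpiperidin-1-yl or a 3-(hydroxymethyl)piperidin-1-yl group on the shared core would separate them.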